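The source may hold more compounds than are shown below. What is called first, only, known or untested is meant among the compounds shown, and "the series" means these compounds.

Working notes on the series. In a functional assay on the whole organism for inhibition, with Echinochloa esculenta as the target (a lower number here means a stronger inhibitor, a higher number a weaker inhibitor), compound 1 `S=c1n(-c2ccc(Br)cc2)c(=S)n2n1CCCC2` gives 66.1 nM, compound 2 `COC(=O)CSc1cc(/N=c2\sc(=S)n3n2CCCC3)c(F)cc1Cl` gives 269 nM, and compound 3 `CC(C)Oc1cc(-n2c(=S)n3n(c2=S)CCCC3)c(F)cc1Cl` gives 12.3 nM. Compound 2 therefore stands at the highest number of the three in this assay, and both of its gaps, to compound 1 and to compound 3, lie beyond the scatter, so it is the weakest of the measured set.

Compound 4 `Fc1cc(Cl)ccc1/N=c1\sc(=S)n2n1CCCC2` is not yet measured. Relative to compound 2 the change is hydrogen in place of ((methoxycarbonyl)methyl)sulfanyl on an aromatic carbon: the ((methoxycarbonyl)methyl)sulfanyl group on the aromatic carbon is removed and a hydrogen takes its place, with the chloro and fluoro groups and the rest of the core kept. No measured pair in the set differs in exactly this way, so the size of the step cannot be read from a shown difference.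

On the present numbers, a modest move toward a lower number is expected, at or just beyond the scatter, with the direction uncertain; the step from compound 2 to compound 4 is estimated as a 1.8-fold lower number from compound 2 to compound 4 (0.25 log units; within the scatter). For compound 4 the expected value in this assay is 150 nM, with a range from 40 nM to 600 nM.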

Compound 4, half-maximal inhibitory concentration: 158 nM
Beside the measured number, compound 4's estimate is 1.1-fold (0.02 log units) below it; low and high end bracket the measured number.
By their numbers in this assay, from the lowest: compound 3; then compound 1; then compounds 4 and 2 (each within the scatter of the next).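

Among the compounds shown here, the first pair in the set that differs in one place shows that, in this assay, hydrogen in place of ((methoxycarbonyl)methyl)sulfanyl gives a 1.7-fold lower number from compound 2 to compound 4 (0.23 log units; within the scatter) at this aromatic carbon, ortho to the chloro group and para to the fluoro group. The whole ((methoxycarbonyl)methyl)sulfanyl group can therefore be lost here with no step beyond the scatter, so the number of compound 2 does not depend measurably on that group. No supporting data bear on the reason for this result.

Still open, on these data alone, is whether an amine, a carboxylic acid or a longer alkylsulfanyl chain on this aromatic carbon would give a step beyond the scatter. Also open, as far as these compounds go, is how a hydrogen at this place would read on the core of compound 3.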